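Chlorobenzyl in place of pentyl on the compound 1 core

The source may report more compounds than this note shows. Statements on the series, on what has been measured and on what is new or still open speak of the compounds shown alone.

Measured so far:
- compound 1, `CCCCCc1nn(C[C@H]2CCCN2C)c(=O)c2ccccc12`: 1000 nM
- compound 2, `CN1CCC(n2nc(Cc3ccc(Cl)cc3)c3ccccc3c2=O)CC1`: 6.31 nM

Both numbers come from an assay for binding affinity to Alpha-1B adrenergic receptor (Homo sapiens); a lower number here means a stronger inhibitor, a higher number a weaker inhibitor. Going by the values given here, compound 1 stands at the higher of the two, and the gap to compound 2 is well beyond the scatter of this assay, so compound 1 is the weaker of the two measured compounds; no single-point step links the two, as they differ in more than one place, and only their two values can be compared.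

Compound 3, `CN1CCC[C@@H]1Cn1nc(Cc2cccc(Cl)c2)c2ccccc2c1=O`, has not been measured. Against compound 1 it shows one change, (3-chlorophenyl in place of butyl on a saturated chain carbon bound to an aromatic carbon). Compound 3 keeps the saturated chain and the substituted five-membered amine of compound 1 and takes up the chlorobenzyl motif that compound 2 carries. A large step toward a lower number is expected, a 40-fold lower number from compound 1 to compound 3 (1.60 log units; beyond the scatter), since compound 2 with its chlorobenzyl gives 6.31 nM in this assay, though compound 2 differs in the amine part and in the position of the chlorine, so the comparison is loose. Compound 3 is estimated at 25 nM in this assay, within a range from 4 nM to 160 nM.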

Compound 3, inhibition constant: 631 nM
The estimate for compound 3 lay 25-fold (1.40 log units) below the measured number; measured number outside the range, above it.
By their numbers in this assay, from the lowest: compound 2; then compounds 3 and 1 (each within the scatter of the next).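

In this assay, replacing pentyl with 3-chlorobenzyl on the core of compound 1 gives no readable difference: the step is a 1.6-fold lower number from compound 1 to compound 3 (0.20 log units; within the scatter) at this site on a saturated chain carbon bound to an aromatic carbon. At this position and with this amine part, the butyl and the 3-chlorophenyl therefore cannot be told apart by this read-out, and a chlorobenzyl group alone is not enough to account for the value of compound 2, 6.31 nM in this assay. No supporting measurement bears on this result.

Compound 2 differs from compound 3 in both the amine part and the position of the chlorine, so the data do not show which of these two differences, or what combination of them, goes with the value of compound 2. Also open, as far as these compounds go, is how a plain benzyl group without chlorine, or a longer chain such as octyl, would read at this position on the core of compound 1.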